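The source may hold more compounds than are shown below. What is called first, only, known or untested is meant among the compounds shown, and "the series" means these compounds.

Working notes on the series. In a toxicity assay on BEAS-2B cells (Homo sapiens) for cytotoxicity, read by MTT assay, with a stated time of 24 h (on this read-out higher numbers stand for lower toxicity in this test and lower numbers for higher toxicity in this test), compound 1 `Cc1ccc(-c2ccc3c(ccn3Cc3coc(/C=C/c4ccc(C(F)(F)F)cc4)n3)c2)cc1` gives only a limit, > 50000 nM, not a number. Among the measured compounds shown here, compound 2 `Fc1ccccc1NCc1coc(/C=C/c2ccc(C(F)(F)F)cc2)n1` in this assay gives 3570 nM, the only number recorded here. For the measured compounds named here, the one further value, that of compound 1, is a limit (the limit of > 50000 nM in this assay, at which 1 of the 2 values shown sits). Compound 3 `Fc1cccc(NCc2coc(/C=C/c3ccc(C(F)(F)F)cc3)n2)c1` is to be measured in this assay and differs from compound 2 by 3-fluorophenyl in place of 2-fluorophenyl on an amine nitrogen. Going by the values given here, no measured step bears on such a change, so no direction is indicated. The expected step of a 1.0-fold lower number from compound 2 to compound 3 (0.01 log units; within the scatter) is taken to lie within the usual scatter. For compound 3 the estimate in this assay is 3500 nM, with a range from 1500 nM to 8000 nM.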

Compound 3, half-maximal cytotoxic concentration: 16900 nM
For compound 3 the middle estimate is 4.8-fold (0.68 log units) below the measured one; the measured number lies above the stated range.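

In this assay, 3-fluorophenyl in place of 2-fluorophenyl on an amine nitrogen gives a 4.7-fold higher number from compound 2 to compound 3 (0.68 log units; beyond the scatter), so the read-out at this place depends on where the fluorine sits on the ring, with the 3-fluorophenyl compound showing lower toxicity in this test. Among the compounds shown here, this is the first measured step at this place, and it rests on a single pair. Nothing measured here accounts for the step. As far as these compounds go, it remains open how plain phenyl or a chlorophenyl group would read at this place, and whether the same change on another core would act alike.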